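Moving the Indole Fluorine on Two Hydroxamate Cores

This account rests on a few compounds, and the source may have more. Where it says the series, first, only, none or still open, it means among the compounds named here.

Two hydroxamates on a shared core, compound 1 `O=C(COc1ccc(CN2CC=C(c3c[nH]c4cccc(F)c34)CC2)c(F)c1)NO` and compound 2 `O=C(COc1ccc(CN2CC=C(c3c[nH]c4ccc(F)cc34)CC2)c(F)c1)NO`, were tested in a functional assay on SW480 cells (Homo sapiens) for antiproliferative activity, with a stated time of 72 h; a higher number here means a weaker inhibitor, a lower number a stronger inhibitor. Compound 2 gives 3860 nM, and compound 1 gives 5560 nM. The change between them is 4-fluoro-1H-indol-3-yl in place of 5-fluoro-1H-indol-3-yl on a double-bonded ring carbon, and it made a 1.4-fold higher number from compound 2 to compound 1 (0.16 log units; within the scatter). Compound 3 `O=C(COc1ccc(C(=O)N2CC=C(c3c[nH]c4ccc(F)cc34)CC2)cc1)NO` rests on a different core; the difference between the two cores is not broken down here. In this assay compound 3 reaches only a limit, > 5000 nM (the limit of > 5000 nM in this assay, at which 1 of the 3 values shown sits). Compound 4 `O=C(COc1ccc(C(=O)N2CC=C(c3c[nH]c4cccc(F)c34)CC2)cc1)NO` arises from compound 3 by the same change, (4-fluoro-1H-indol-3-yl in place of 5-fluoro-1H-indol-3-yl on a double-bonded ring carbon). The step from compound 3 to compound 4 is expected to be small, a step that the limit leaves unreadable from compound 3 to compound 4, because a 1.4-fold higher number from compound 2 to compound 1 (0.16 log units; within the scatter) stayed within the scatter. Compound 4 is accordingly expected to give about 7000 nM, quite possibly again reported only as a limit.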

Compound 4, half-maximal inhibitory concentration: 1490 nM
Compound 4: middle estimate off by 4.7-fold (0.67 log units), on the high side; measured number below the stated range.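

In this assay, putting 4-fluoro-1H-indol-3-yl in place of 5-fluoro-1H-indol-3-yl made an at least 3.3-fold lower number from compound 3 to compound 4 (0.52 log units; beyond the scatter), so across these two pairs the size of the step did not carry from one core to the other: the same change on two cores in this assay, a 1.4-fold higher number (0.16 log units; within the scatter) from compound 2 to compound 1 and an at least 3.3-fold lower number (0.52 log units; beyond the scatter) from compound 3 to compound 4, at least 4.8-fold (0.68 log units) apart, beyond the scatter of two such steps

Compound 3 is recorded only as a limit, > 5000 nM, which leaves the full size of its step unknown. Two pairs show that the outcome of this change can depend on the core, but not which part of the difference between the cores matters.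

As far as these compounds go, it remains open whether a chlorine in place of the fluorine would follow the same course on each core. Also open, from the compounds shown here alone, is how the change would behave with a longer chain leading to the hydroxamate.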